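This account rests on a few compounds, and the source may have more. Where it says the series, first, only, none or still open, it means among the compounds named here.

Three measured compounds share one core, and all sit within a narrow band in an assay on HEK293 cells for positive allosteric modulation of metabotropic glutamate receptor 3 (Rattus norvegicus), read by thallium flux, with a stated time of 2.5 min; on this read-out lower numbers stand for smaller maximal responses and higher numbers for larger maximal responses. Compound 1 `Cc1c(OCCCCOc2ccc(C(=O)O)cc2)ccc(C(=O)CC2CCCC2)c1O` gives 26.7%, compound 2 `Cc1c(OCCCCOc2ccccc2C(=O)O)ccc(C(=O)CC2CCCC2)c1C` gives 28%, and compound 3 `Cc1c(OCCCCOc2ccc(C(=O)O)cc2F)ccc(C(=O)CC2CCCC2)c1O` gives 31.2%. Compound 3 has the highest of the three numbers, yet its gaps to compound 2 and to compound 1 both lie within the scatter, so no ordering can be drawn from them.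

Among the compounds with values here, only one single-point step has been measured: a number 4.5 percentage points higher from compound 1 to compound 3 (within the scatter), a change that did not move the read-out beyond the scatter.

Compound 4 `Cc1c(OCCCCOc2ccccc2C(=O)O)ccc(C(=O)CC2CCCC2)c1O` is not yet measured. It differs from compound 3 by 2-carboxyphenyl in place of 4-carboxy-2-fluorophenyl on an oxygen on a saturated carbon. Within the data shown here, no measured step tests the move of the carboxy group from the 4-position to the 2-position, or the loss of the fluorine together with it; the one measured step, from compound 1 to compound 3, concerns only the fluorine and was small. Compound 2 carries the 2-carboxyphenyl and returns a number within the scatter of the other two, which offers no sign that this group shifts the maximal response. Compound 4 is therefore expected to show a number 3.2 percentage points lower from compound 3 to compound 4 (within the scatter), a step of no consequence beyond the scatter. The estimate for compound 4 in this assay is 28%, expected to fall between 16% and 42%.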

Compound 4, largest response reached (reported as percent of maximum), in percent of the reference or control that the assay uses: 32.9%
For compound 4 the middle estimate is 4.9 percentage points below the measured one; the range from low to high includes it.
By their numbers in this assay, from the lowest: compounds 1, 2, 3 and 4 (each within the scatter of the next).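

In this assay, 2-carboxyphenyl in place of 4-carboxy-2-fluorophenyl on an oxygen on a saturated carbon gives a number 1.7 percentage points higher from compound 3 to compound 4 (within the scatter) and, in place of 4-carboxyphenyl at the same place, gives a number 6.2 percentage points higher from compound 1 to compound 4 (within the scatter) as its result. Within the data shown here, this is the first measured test of these exchanges, and it shows that the read-out does not separate these three groups at this position, with or without the fluorine. The hydroxy on the aromatic carbon can now be compared directly as well: hydroxy in place of methyl gives a number 4.9 percentage points higher from compound 2 to compound 4 (within the scatter) and so also leaves the maximal response unresolved, while no other kind of data is available to account for any of these results.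

On these data alone, it remains open whether a tetrazole or a primary amide in place of the carboxylic acid, or a longer chain joining the two oxygens, would move the maximal response beyond the scatter. The same question stands for a cyclohexyl group in place of the cyclopentyl group, as the compounds shown do not reach it.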